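Acyl variation on the sulfonamide side chain: cyclopropyl analogue

A few compounds are considered here, and "the series" means these few. Any claim that something is new, unique, unknown or untested is made for them only; others in the source may bear on it.

Among the measured compounds shown here, compound 1 `CC(C)(C)NC(=O)NCCS(=O)(=O)NC(=O)c1ccc(Nc2nc(NC3(c4ccc(Cl)cc4)CC3)nc(OCC(F)(F)F)n2)cc1` carries a (tert-butyl)carbamoyl group on the side chain and stands highest of the two numbers so far in an ADME assay on microsomes from liver (Homo sapiens) for metabolic stability, with a stated time of 10 min (a higher number here means that more of the compound is left, a lower number that less of the compound is left), where compound 1 gives 96%. Its nearest neighbour is compound 2 `CC(C)C(=O)NCCS(=O)(=O)NC(=O)c1ccc(Nc2nc(NC3(c4ccc(Cl)cc4)CC3)nc(OCC(F)(F)F)n2)cc1`, which in this assay gives 86%; the step of a number 10 percentage points lower from compound 1 to compound 2 (within the scatter) lies within the scatter, so the two numbers cannot be ordered.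

Compound 3 `O=C(NS(=O)(=O)CCNC(=O)C1CC1)c1ccc(Nc2nc(NC3(c4ccc(Cl)cc4)CC3)nc(OCC(F)(F)F)n2)cc1` is the next candidate. Against compound 1 the change reads (cyclopropyl in place of (tert-butyl)amino on a carbonyl carbon). For the measured compounds named here, the single measured step that bears on it is the one from the (tert-butyl)amino group to isopropyl, a number 10 percentage points lower from compound 1 to compound 2 (within the scatter), on the same carbonyl carbon, which stayed within the scatter. Cyclopropyl, like isopropyl, is a carbon-only group with no hydrogen-bond donor or acceptor, so given a number 10 percentage points lower from compound 1 to compound 2 (within the scatter) the step of a number 6 percentage points lower from compound 1 to compound 3 (within the scatter) is expected to be small, at most a slight drop and not beyond the scatter. Compound 3 is therefore estimated at 90% in this assay, with a range from 78% to 98%.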

Compound 3, percent of the compound remaining: 90%
Beside the measured number, compound 3's estimate shows no gap at the digits printed; the measured number falls inside the stated range.
By their numbers in this assay, from the lowest: compounds 2, 3 and 1 (each within the scatter of the next).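

In this assay the carbonyl carbon of the side chain now also carries a ring: cyclopropyl in place of (tert-butyl)amino gives a number 6 percentage points lower from compound 1 to compound 3 (within the scatter) and cyclopropyl in place of isopropyl gives a number 4 percentage points higher from compound 2 to compound 3 (within the scatter) so that neither step can be read as a change. The first of these steps removes a group of 5 heavy atoms with 1 hydrogen-bond donor and brings in a three-membered ring of 3 heavy atoms with no donor, yet the numbers stay within the scatter, and among these three compounds neither the donor nor the ring separates the values. Nothing measured here says why the values stay together.

Still open, going by these compounds, is whether any group on this carbonyl carbon moves the number in this assay beyond the scatter, for instance an amine, a carboxylic acid or a longer alkyl chain. All three compounds share the core of compound 1, so they say nothing about how changes elsewhere in the molecule would read in this assay.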